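Swapping the amide substituent on a shared core

A few compounds are considered here, and "the series" means these few. Any claim that something is new, unique, unknown or untested is made for them only; others in the source may bear on it.

Measured compounds and values:
- Compound 1 `Cc1nc(S(C)(=O)=O)ccc1Oc1ncnc(OC2CCN(C(=O)OC3(C(F)(F)F)COC3)CC2)c1F`: 29.3 nM
- Compound 2 `Cc1nc(S(C)(=O)=O)ccc1Oc1ncnc(OC2CCN(C(=O)C(C)(F)F)CC2)c1F`: 37 nM
- Compound 3 `Cc1nc(S(C)(=O)=O)ccc1Oc1ncnc(OC2CCN(C(=O)C3CCCC3)CC2)c1F`: 72.8 nM

In a functional assay on isolated protein for inhibition of Glucose-dependent insulinotropic receptor (Homo sapiens), read by HTRF and cAMP accumulation (a lower number here means that less compound is needed, a higher number that more compound is needed for the effect), compound 3 gives the highest number of the three. Its nearest neighbour is compound 2, reached by a 2.0-fold higher number from compound 2 to compound 3 (0.29 log units; within the scatter), while the step of a 2.5-fold higher number from compound 1 to compound 3 (0.40 log units; beyond the scatter) is the larger one. Compound 4 `CCc1cnc(C(=O)N2CCC(Oc3ncnc(Oc4ccc(S(C)(=O)=O)nc4C)c3F)CC2)nc1` has not yet been measured. It differs from compound 3 by 5-ethylpyrimidin-2-yl in place of cyclopentyl on a carbonyl carbon. All three measured steps concern the group on this same carbonyl carbon, but each of them exchanges one non-aromatic group for another, and none brings in an aromatic ring with two heteroatoms, so they bear on the step only loosely. Since the step of a 2.0-fold higher number from compound 2 to compound 3 (0.29 log units; within the scatter) and the step of a 2.5-fold higher number from compound 1 to compound 3 (0.40 log units; beyond the scatter) both leave compound 3 with the highest number, a change away from cyclopentyl is expected to give a similar or somewhat lower number, close to compounds 1 and 2. The expected step is a 1.8-fold lower number from compound 3 to compound 4 (0.26 log units; within the scatter). For compound 4 the estimate in this assay is 40 nM, within a range from 12 nM to 130 nM.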

Compound 4, half-maximal effective concentration: 4.7 nM
For compound 4 the middle estimate is 8.5-fold (0.93 log units) above the measured one, outside the stated range (below it).
By their numbers in this assay, from the lowest: compound 4; then compounds 1, 2 and 3 (each within the scatter of the next, the first and the last beyond it).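

In this assay, the group on this carbonyl carbon, bonded to the amide-type nitrogen in a ring, turns out to have far more influence than the non-aromatic groups alone suggested: 5-ethylpyrimidin-2-yl in place of cyclopentyl gives the large step (a 15-fold lower number from compound 3 to compound 4 (1.19 log units; beyond the scatter)). The gain does not depend on cyclopentyl as the reference, as compound 4 also stands clear of the other two groups (a 7.9-fold lower number from compound 2 to compound 4 (0.90 log units; beyond the scatter); a 6.2-fold lower number from compound 1 to compound 4 (0.79 log units; beyond the scatter)). Nothing available explains why this six-membered aromatic ring with 2 hetero atoms has this effect.

The compounds shown do not separate the contribution of the ring nitrogens from that of the ethyl group; a phenyl or an unsubstituted pyrimidin-2-yl on this carbonyl carbon would address that. From the compounds shown here alone, how a propyl or a methoxy group in place of the ethyl would fare also remains open.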